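The source may hold more compounds than are shown below. What is called first, only, known or untested is meant among the compounds shown, and "the series" means these compounds.

Three compounds share one core and differ in the groups attached to it. Compound 1 `Cc1ccc(S(=O)(=O)c2cnc3ccc(Cl)cc3c2N2CCC(C)CC2)cc1` is measured in an assay on isolated protein for displacement of a labelled ligand from metabotropic glutamate receptor 5 (Homo sapiens), with a stated time of 60 min, tested at 1 uM (a higher number here means more inhibition at the concentration tested (going by the name of the read-out), a lower number less inhibition), and gives 95%. Compound 2 `CC1CCN(c2c(S(=O)(=O)c3ccc(Cl)cc3)cnc3ccc(F)cc23)CC1` gives 80% in this assay, and compound 3 `CC1CCN(c2c(S(=O)(=O)c3cc(F)cc(F)c3)cnc3cc(F)ccc23)CC1` gives 77%.

Among these three numbers compound 2 stands second highest. Its nearest neighbour is compound 3, whose number lies within the usual scatter of this assay, so the two cannot be told apart. Its furthest neighbour is compound 1, whose number stands beyond the scatter above that of compound 2.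

Compound 4 `Cc1cc(C)cc(S(=O)(=O)c2cnc3ccc(F)cc3c2N2CCC(C)CC2)c1` has not yet been measured. Compared with compound 2 it carries a different group on the sulfonyl sulfur: 3,5-dimethylphenyl in place of 4-chlorophenyl on a sulfonyl sulfur. Among the compounds with values here, no pair of measured compounds differs in only this one place, so there is no directly comparable step to lean on. Compounds 1 and 2 show that a methyl-bearing ring and a chlorine-bearing ring at this place both give high numbers, but they also differ elsewhere, so only their two values can be read from them.

The step from compound 2 to compound 4 is expected to be small, likely none beyond the scatter, with no change at the digits printed from compound 2 to compound 4 (within the scatter). Compound 4 is therefore estimated at 80%, within a range from 62% to 93%.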

Compound 4, a percentage reported as inhibition, at one concentration (the size of the read-out at that concentration, not a potency): 83%
Compound 4: middle estimate off by 3 percentage points, on the low side; the range from low to high includes it.
By their numbers in this assay, from the lowest: compounds 3, 2 and 4 (each within the scatter of the next); then compound 1.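

Within the data shown here, compounds 2 and 4 differ only in the group on the sulfonyl sulfur, so this is the first clean reading of that place. In this assay, 3,5-dimethylphenyl in place of 4-chlorophenyl gives a number 3 percentage points higher from compound 2 to compound 4 (within the scatter), which means that this exchange of a chlorine-bearing ring for a slightly larger ring of carbon only leaves no change that can be told from scatter. The shared fluorine-bearing core and the methyl-substituted six-membered amine ring stay the same in this pair, so the result applies to these two groups on that background alone, and nothing among the data presented explains why the two groups read alike.

Every group shown on the sulfonyl sulfur is still a six-membered aromatic ring of carbon, so it remains open whether a saturated cyclohexyl ring, a simple methyl group, or a ring carrying a carboxylic acid or an amine would keep the number. The read-out comes from one concentration and is not a potency. Compounds 2 and 4 could also still differ in a full concentration series.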